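The compounds below may be only part of what the source reports. "The series", "measured", "known", "first", "only" and "open" are said of these compounds alone.

In a physicochemical assay for solubility, read by nephelometry, in phosphate buffer, measured as kinetic solubility, with a stated time of 30 min, at pH 6.5 (a higher number here means a more soluble compound, a lower number a less soluble compound), compound 1 `COc1ccc(-c2cc(-c3ccc(S(C)(=O)=O)cc3)cnc2N)cn1` gives 121 ug/mL and compound 2 `Cc1ccc(-c2cc(-c3ccc(S(C)(=O)=O)cc3)cnc2N)cn1` gives 50 ug/mL. Compound 3 `CS(=O)(=O)c1ccc(-c2cnc(N)c(-c3ccc(C(F)(F)F)cc3)c2)cc1` gives < 1.6 ug/mL, which is a limit of the assay and not a number. Compound 4 `CS(=O)(=O)c1ccc(-c2cnc(N)c(-c3ccc(C#N)cc3)c2)cc1` differs from compound 3 in one place, with cyano in place of trifluoromethyl on an aromatic carbon, para to a large group (cyano in place of trifluoromethyl on an aromatic carbon). Within the data shown here, no measured step covers this exact exchange. The closest guide is a 2.4-fold lower number from compound 1 to compound 2 (0.38 log units; beyond the scatter), which has methyl in place of methoxy on an aromatic carbon. It involves different groups, so it offers only a rough sense of how far one such exchange can move the read-out. A step of that modest size or somewhat larger is expected. A higher number is expected for compound 4 because compound 3 reports only a limit of the assay, < 1.6 ug/mL. The expected move is an at least 3.7-fold higher number from compound 3 to compound 4 (0.57 log units; beyond the scatter). For compound 4 the estimate is 6 ug/mL, with an expected range of 2 ug/mL to 30 ug/mL.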

Compound 4, solubility: 1.6 ug/mL
The estimate for compound 4 lay 3.8-fold (0.57 log units) above the measured number; measured number outside the range, below it.
By their numbers in this assay, from the lowest: compound 4; then compound 2; then compound 1.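

In this assay compound 3 gives < 1.6 ug/mL, which is a limit of the assay and not a number. Cyano in place of trifluoromethyl gives a number no lower from compound 3 to compound 4 (the limit leaves the size open), so the size of this exchange cannot be read. The result does show what happens when the whole group changes: 4-cyanophenyl in place of 6-methylpyridin-3-yl gives a 31-fold lower number from compound 2 to compound 4 (1.49 log units; beyond the scatter), and 4-cyanophenyl in place of 6-methoxypyridin-3-yl gives a 76-fold lower number from compound 1 to compound 4 (1.88 log units; beyond the scatter). Both steps are large, whereas the earlier exchange of methoxy for methyl was modest, at a 2.4-fold lower number from compound 1 to compound 2 (0.38 log units; beyond the scatter).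

From the compounds shown here alone, the true gap between the trifluoromethyl and cyano compounds stays open, and one value in the set rests on a limit: the limit of < 1.6 ug/mL in this assay, at which 1 of the 4 values shown sits. Also open is where an amine or a carboxylic acid would fall in place of cyano on this aromatic carbon.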